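Swapping the amide aryl ring: 3-chlorophenyl to 4-ethylphenyl

The source may hold more compounds than are shown below. What is called first, only, known or untested is meant among the compounds shown, and "the series" means these compounds.

Measured so far:
compound 1, `Cc1ccc(NC(=O)c2ccc(CN3CCN(C)CC3)cc2)cc1-n1cc(-c2cnc3cccnn23)cn1`, 10800 nM
compound 2, `Cc1ccc(NC(=O)c2cccc(Cl)c2)cc1-n1cc(-c2cnc3cccnn23)cn1`, > 20000 nM

Both compounds share the same core; they differ only in the aryl group carried on the amide carbonyl. In a functional assay on U-937 cells (Homo sapiens) for antiproliferative activity, read by CCK-8 assay, with a stated time of 24 h (a lower number here means a stronger inhibitor, a higher number a weaker inhibitor), compound 1 gives 10800 nM, a weak inhibitor. For compound 2 the assay reports only a limit, > 20000 nM; this is the edge of what the assay can measure, and among the two values shown it is the one that sits at that edge (the limit of > 20000 nM in this assay, at which 1 of the 2 values shown sits). So compound 2 stands at the weak end of the numbers shown, with no exact value.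

Compound 3, `CCc1ccc(C(=O)Nc2ccc(C)c(-n3cc(-c4cnc5cccnn45)cn3)c2)cc1`, differs from compound 2 in one place: 4-ethylphenyl in place of 3-chlorophenyl on a carbonyl carbon. Going by the values given here, since both measured compounds are weak, and one is only a limit, there is no measured step here that tells how such a change moves the read-out. The expectation is therefore that compound 3 stays weak, with a step from compound 2 to compound 3 of a number no higher from compound 2 to compound 3 (the limit leaves the size open), which is not beyond the scatter. Compound 3 is estimated at 20000 nM, with a range from 8000 nM to 50000 nM.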

Compound 3, half-maximal inhibitory concentration: > 20000 nM
Compound 3: no number, only a limit; the forecaster's own chance of this, stated with the estimate: 55%; the middle value sits exactly at the limit.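

In this assay compound 3 gives > 20000 nM and this is a limit, not a number. Compound 2 also stands only at a limit, so the swap of 3-chlorophenyl for 4-ethylphenyl on a carbonyl carbon cannot be read, and no size can be given for it. Going by these compounds alone, the one readable step is methyl in place of 4-methylpiperazin-1-yl on a saturated chain carbon bound to an aromatic carbon, which gives an at least 1.8-fold higher number from compound 1 to compound 3 (0.26 log units; that floor lies within the scatter) and so does not separate the two compounds. Compound 1 remains the only one of the three with an exact number, and a second aryl group on the amide now ends at the same edge of the assay: the limit of > 20000 nM in this assay, at which 2 of the 3 values shown sit.

Going by these compounds, it remains open how far compound 2 and compound 3 lie past that limit, and so whether 3-chlorophenyl and 4-ethylphenyl differ at all in this read-out. On these data alone, it is also open whether a morpholine ring or a carboxylic acid, set on the saturated chain carbon where compound 1 carries 4-methylpiperazin-1-yl, would give an exact number or a limit.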